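The source may report more compounds than this note shows. Statements on the series, on what has been measured and on what is new or still open speak of the compounds shown alone.

Measured compounds:
compound 1, `Cc1cc(C(=O)O)nn1-c1ccc(S(=O)(=O)NC(=S)NCc2ccccc2)cc1`: < 2%
compound 2, `Cc1cc(C(=O)O)nn1-c1ccc(S(=O)(=O)NC(=O)NCc2ccccc2)cc1`: 0%

In a functional assay on the whole organism (blood, strain albino) with Mus musculus as the target, with stated times of 6 days and 4 h, at a dose of 0.4 mmol/kg by the oral route (a lower number here means less inhibition, a higher number more inhibition at the dose given (going by the name of the read-out)), compound 1 gives only a limit, < 2%, which is not a number. In the same assay compound 2 gives 0%. Compound 1 therefore sits at the bottom of the read-out, at the point described by the limit of < 2% in this assay, at which 1 of the 2 values shown sits. Compound 3, `CCNC(=S)NS(=O)(=O)c1ccc(-n2nc(C(=O)O)cc2C)cc1`, differs from compound 1 by methyl in place of phenyl on a saturated chain carbon bound to an amide-type nitrogen. Among the compounds with values here, no measured pair shows this change, so nothing indicates its effect. Since compound 1 stands at < 2%, no step beyond the scatter is expected in either direction. Compound 3 is expected to give about 1%, between 0% and 8%. The expected step is a step that the limit leaves unreadable from compound 1 to compound 3.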

Compound 3, a percentage reported as inhibition, in the whole organism at one dose (the size of the read-out at that dose, not a potency): -2%
Compound 3: the middle estimate sits 3 percentage points above what was measured; the measured number lies below the stated range.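

No step can be read from compound 1 to compound 3, because the value of compound 1 is a limit and not a number: the limit of < 2% in this assay, at which 1 of the 3 values shown sits. Going by these compounds, what benzyl to ethyl does in this assay stays open, as does whether any compound of this kind gives clear inhibition at that dose.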